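A few compounds are considered here, and "the series" means these few. Any claim that something is new, unique, unknown or untested is made for them only; others in the source may bear on it.

Of the compounds shown here, three that share one core have been tested in an ADME assay on HepG2 cells (Homo sapiens) for cytotoxicity, read by MTT assay, with a stated time of 72 h; on this read-out higher numbers stand for lower toxicity in this test and lower numbers for higher toxicity in this test. Compound 1 `Oc1ccccc1/C=N/c1sc2c(c1-c1nc3ccccc3s1)CCC2` gives 156 ug/mL. Compound 3 `Oc1ccccc1/C=N/c1sc2c(c1-c1nc3cc(Cl)ccc3s1)CCC2` differs from it by a single change, (chloro in place of hydrogen on an aromatic carbon), and gives 210 ug/mL; the step of a 1.3-fold higher number from compound 1 to compound 3 (0.13 log units; within the scatter) is small. Compound 2 `C(=C/c1ccccc1)\C=N\c1sc2c(c1-c1nc3ccccc3s1)CCCC2` gives 467 ug/mL, the highest of the three, with its gap to compound 3 and to compound 1 both beyond the scatter. The difference between the core of compound 2 and the core of compound 1 is not broken down here.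

Compound 4 `Clc1ccc2sc(-c3c(/N=C/C=C/c4ccccc4)sc4c3CCCC4)nc2c1` has not yet been measured in this assay. It stands to compound 2 as compound 3 stands to compound 1: chloro in place of hydrogen on an aromatic carbon. The place of the change is the same word for word in both pairs, so it is the same change, made twice among these four compounds. Because the earlier step of a 1.3-fold higher number from compound 1 to compound 3 (0.13 log units; within the scatter) stayed within the scatter, the expected step is a 1.2-fold higher number from compound 2 to compound 4 (0.08 log units; within the scatter), a shift of similar size and direction. The expectation rests on that single earlier pair alone, and on the value 467 ug/mL of compound 2 as the starting point. For compound 4 the estimated value is 560 ug/mL, with a likely range from 320 ug/mL to 980 ug/mL.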

Compound 4, half-maximal cytotoxic concentration: 114 ug/mL
The estimate for compound 4 lay 4.9-fold (0.69 log units) above the measured number, outside the stated range (below it).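

In this assay, chloro in place of hydrogen on an aromatic carbon gives a 4.1-fold lower number from compound 2 to compound 4 (0.61 log units; beyond the scatter), so on this core the change moves the number toward higher toxicity in this test. Set beside the small step on the other core, this shows that the same change does not carry over from one core to the other with the same size or direction: the same change on two cores in this assay, a 1.3-fold higher number (0.13 log units; within the scatter) from compound 1 to compound 3 and a 4.1-fold lower number (0.61 log units; beyond the scatter) from compound 2 to compound 4, 5.5-fold (0.74 log units) apart, beyond the scatter of two such steps. Among the compounds shown here, it does not show which part of the difference between the core of compound 1 and the core of compound 2 matters, why the two steps part ways, or how the change would behave on any further core, since only two pairs are at hand.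

The compounds shown leave open whether the lower number of compound 4 belongs to chloro itself or would also appear with another group on the same aromatic carbon, such as fluoro, methoxy or an amine. They also leave open how a carboxylic acid at that place would behave on each of the two cores, and so whether either step is typical of this series.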